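Shortening to a Phenoxyethyl Chain without the Chlorine

This account rests on a few compounds, and the source may have more. Where it says the series, first, only, none or still open, it means among the compounds named here.

For the measured compounds named here, compound 3 `O=C(O)c1csc([C@H]2CC[C@@H]3[C@@H](COc4ccccc4Cl)[C@H](O)C[C@@H]3O2)n1` is the only compound here that gives a number in an assay on HEK293 cells for agonist activity at prostaglandin E2 receptor EP2 subtype (Homo sapiens), read by a beta-galactosidase reporter and beta-arrestin recruitment, with a stated time of 90 min; on this read-out lower numbers stand for an effect already at smaller amounts and higher numbers for an effect only at larger amounts of compound: compound 3 gives 203 nM. Compound 1 `Cc1ccc(OC[C@@H]2[C@H]3CC[C@H](c4nc(C(=O)O)cs4)O[C@H]3C[C@H]2O)cc1` gives only a limit of the assay, and in this assay compound 1 gives > 10000 nM. Compound 2 `O=C(O)c1csc([C@H]2CC[C@@H]3[C@@H](CCCOc4ccccc4)[C@H](O)C[C@@H]3O2)n1` likewise gives only a limit; in this assay compound 2 gives > 10000 nM. Both limits sit at the limit of > 10000 nM in this assay, at which 2 of the 3 values shown sit. Compound 4 `O=C(O)c1csc([C@H]2CC[C@@H]3[C@@H](CCOc4ccccc4)[C@H](O)C[C@@H]3O2)n1` differs from compound 3 by phenoxymethyl in place of 2-chlorophenoxy on a saturated chain carbon bound to a saturated ring carbon. Going by the values given here, two measured steps bear on this change. The step of an at least 49-fold lower number from compound 1 to compound 3 (1.69 log units; beyond the scatter) shows that exchanging the ring substituent alone moved the number a long way; the step of an at least 49-fold lower number from compound 2 to compound 3 (1.69 log units; beyond the scatter) shows that chain length and the chlorine together did the same. The step that the two limits leave unreadable from compound 1 to compound 2 says nothing readable. Since compound 4 loses the chlorine and lengthens the chain, a step of a 25-fold higher number from compound 3 to compound 4 (1.39 log units; beyond the scatter) towards a higher number is expected, and compound 4 is estimated at 5000 nM, with a likely range from 800 nM to 30000 nM.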

Compound 4, half-maximal effective concentration: > 10000 nM
Compound 4: only a limit was reported; the forecaster's own chance of this, stated with the estimate: 55%; middle value at least 2.0-fold (0.30 log units) away from the limit.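

The (2-chlorophenoxy)methyl group of compound 3 cannot be exchanged for 2-phenoxyethyl at this saturated chain carbon without a large change, an at least 49-fold higher number from compound 3 to compound 4 (1.69 log units; beyond the scatter). From the compounds shown here alone, compound 4 gives only a limit of the assay, so the full size of that step remains unknown, and the steps to compound 4 from compound 1 and from compound 2 connect two limits and cannot be read. Among these chains without a chlorine, the 2-phenoxyethyl group of compound 4 therefore gives no readable number, and compound 3 remains the only compound with one: the limit of > 10000 nM in this assay, at which 3 of the 4 values shown sit.

The chlorine and the chain changed together in this step, so their separate contributions remain unresolved. A 2-(2-chlorophenoxy)ethyl group would separate them, while a (2-fluorophenoxy)methyl group would test whether another halogen can stand in for chlorine.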